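This account rests on a few compounds, and the source may have more. Where it says the series, first, only, none or still open, it means among the compounds named here.

Compound 1 `CCOC(=O)c1c(-c2cccc(OC(F)(F)F)c2)[nH]c2cc(OC)ccc2c1=O`, compound 2 `CCOC(=O)c1c(-c2cccc(OC(F)(F)F)c2)[nH]c2cc(C(F)(F)F)ccc2c1=O` and compound 3 `CCOC(=O)c1c(-c2cccc(OC(F)(F)F)c2)[nH]c2cc(OC)c(F)cc2c1=O` were all tested in an ADME assay on HepG2 cells (Homo sapiens) for cytotoxicity, read by luminescence, with a stated time of 72 h; a lower number here means that less compound is needed, a higher number that more compound is needed for the effect. Compound 1 gives > 21500 nM, which is a limit and not a number. Compound 2 gives > 21500 nM, again a limit. Compound 3 gives > 21500 nM, so it too stands only on a limit. The set offers a single reading: the limit of > 21500 nM in this assay, at which 3 of the 3 values shown sit.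

Compound 4 `CCOC(=O)c1c(-c2cccc(-c3nc(C)c(C)s3)c2)[nH]c2cc(OC)c(F)cc2c1=O` departs from compound 3 in one place: 4,5-dimethyl-1,3-thiazol-2-yl in place of trifluoromethoxy on an aromatic carbon, with 4,5-dimethyl-1,3-thiazol-2-yl in place of trifluoromethoxy on an aromatic carbon. Two measured steps exist, a step that the two limits leave unreadable from compound 1 to compound 2 and a step that the two limits leave unreadable from compound 1 to compound 3, but neither has a size that can be read, and neither replaces trifluoromethoxy. They therefore give no size to carry over. With nothing firmer to go on, only a small move towards less compound being needed is expected in this assay, and compound 4 may well report a limit too. The expected change is an at least 1.1-fold lower number from compound 3 to compound 4 (0.07 log units; that floor lies within the scatter). For compound 4 the estimated value is 18000 nM, within an expected range of 6000 nM to 40000 nM.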

Compound 4, half-maximal effective concentration: > 21500 nM
Compound 4 ended at the assay's limit; the forecaster's own chance of this, stated with the estimate: 60%; at least 1.1-fold (0.07 log units) between middle value and limit.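

In this assay compound 4 gives > 21500 nM, which is a limit and not a number, so no size can be read for the step from compound 3 to compound 4. The compounds shown leave open whether any change on the shared core moves the value in this assay, as they share a single reading: the limit of > 21500 nM in this assay, at which 4 of the 4 values shown sit.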